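The source may hold more compounds than are shown below. What is called first, only, known or untested is meant among the compounds shown, and "the series" means these compounds.

Measured so far: compound 2 `COc1ccc(Nc2nc(N)c(C(=O)c3ccccc3OC)s2)cc1` with 31 nM; compound 3 `COc1ccc(Nc2nc(N)c(C(=O)c3ccccc3)s2)cc1` with 850 nM; compound 1 `COc1cccc(Nc2nc(N)c(C(=O)c3ccccc3)s2)c1` with 8200 nM, all in a functional assay on L1210 cells (Mus musculus) for antiproliferative activity, read by cell counting, with a stated time of 2 days; a higher number here means a weaker inhibitor, a lower number a stronger inhibitor.

Compound 2 stands lowest of the three, with compound 3 nearest and compound 1 furthest. Compound 4 `COc1ccccc1C(=O)c1sc(Nc2ccccc2)nc1N` differs from compound 2 by hydrogen in place of methoxy on an aromatic carbon. Among the compounds with values here, no measured step removes this group; the one step recorded, a 27-fold higher number from compound 2 to compound 3 (1.44 log units; beyond the scatter), removes a methoxy from the other aromatic ring and is large. Compounds 1 and 3, which differ only in where the aniline methoxy sits, show that this ring also matters. Compound 4 is therefore expected to give a higher number, by about a 13-fold higher number from compound 2 to compound 4 (1.11 log units; beyond the scatter), with 400 nM as the estimate and a range from 60 nM to 2500 nM.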

Compound 4, half-maximal inhibitory concentration: 1100 nM
Compound 4: the middle estimate sits 2.8-fold (0.44 log units) below what was measured; measured number inside the range.
By their numbers in this assay, from the lowest: compound 2; then compounds 3 and 4 (each within the scatter of the next); then compound 1.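

In this assay, the methoxy para to a large group proves to count on its own: replacing it with hydrogen gives a 35-fold higher number from compound 2 to compound 4 (1.55 log units; beyond the scatter). Earlier, a large step had been recorded only for the methoxy on the other aromatic ring, whereas each methoxy of compound 2 now has a large step of its own. Nothing available explains this loss. The compounds shown leave open whether the methoxy is specifically required at this place, or whether an ethoxy or an amine there would keep the number of compound 2.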